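A few compounds are considered here, and "the series" means these few. Any claim that something is new, unique, unknown or untested is made for them only; others in the source may bear on it.

Measured in a functional assay on HCT-116 cells (Homo sapiens) for inhibition, read by MTT assay, with a stated time of 72 h; on this read-out lower numbers stand for stronger inhibition and higher numbers for weaker inhibition:
- compound 1 `O=C1/C(=C\c2ccccc2)c2c(ncn2COCc2ccccc2)CCN1Cc1ccccc1` gives 20000 nM
- compound 2 `Cc1ccccc1CN1CCc2ncn(COCc3ccccc3)c2/C(=C/c2ccccc2)C1=O` gives 24700 nM

Only these two compounds have been measured, and they stand level. Among the compounds with values here, the step of a 1.2-fold higher number from compound 1 to compound 2 (0.09 log units; within the scatter) lies within the scatter, so compound 1 sits in the same range as its single neighbour.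

Compound 3 `O=C1/C(=C\c2ccccc2)c2[nH]cnc2CCN1Cc1ccccc1` is still to be measured. It carries hydrogen in place of (benzyloxy)methyl on an aromatic nitrogen, and the counted change is hydrogen in place of (benzyloxy)methyl on an aromatic nitrogen in full.

Within the data shown here, the one measured step, a 1.2-fold higher number from compound 1 to compound 2 (0.09 log units; within the scatter) as seen above, concerns a methyl on an aromatic carbon elsewhere in the molecule. Both measured compounds keep the (benzyloxy)methyl group, so no measurement tests its loss. The change is nevertheless large, and a moderate move towards a higher number is expected, with wide uncertainty in either direction.

The expected change is a 2.0-fold higher number from compound 1 to compound 3 (0.30 log units; within the scatter) as an estimate only. For compound 3 the estimated value is 40000 nM with an expected range from 12000 nM to 100000 nM in this read-out.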

Compound 3, half-maximal inhibitory concentration: > 100000 nM
Compound 3: a limit, no number; the forecaster's own chance of this, stated with the estimate: 30%; middle value at least 2.5-fold (0.39 log units) from the limit.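

In this assay compound 3 gives > 100000 nM, which is a limit of the assay and not a number. Among the compounds shown, this is the only change on the aromatic nitrogen, and replacing the whole (benzyloxy)methyl with hydrogen gives an at least 5.0-fold higher number from compound 1 to compound 3 (0.69 log units; beyond the scatter), so what this nitrogen carries matters for the read-out in a way that compound 1 and compound 2, which both keep the group, could not show. The step has only a lower bound and its full size stays unknown, as the reading for compound 3 is a limit: the limit of > 100000 nM in this assay, at which 1 of the 3 values shown sits.

The compounds shown leave open which part of the (benzyloxy)methyl matters, as only the complete group and hydrogen appear on this nitrogen. Whether a plain methyl, a benzyl group or a longer alkyl chain on the same nitrogen would give a number close to that of compound 1 or one closer to the limit of compound 3 remains an open question, and so does the effect of the same loss on compound 2.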